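This account rests on a few compounds, and the source may have more. Where it says the series, first, only, none or still open, it means among the compounds named here.

Measured so far:
compound 1, `CN1CCN(c2nc(N)nc(CCCOc3ccc(Cl)c(Cl)c3)n2)CC1`, gives 1060 nM in an assay on HEK293 cells for displacement of a labelled ligand from 5-hydroxytryptamine receptor 6 (Homo sapiens), read by scintillation counting, with a stated time of 1 h; a higher number here means a weaker inhibitor, a lower number a stronger inhibitor.
compound 2, `CCCCC(Oc1cc(Cl)ccc1Cl)c1nc(N)nc(N2CCN(C)CC2)n1`, gives 17 nM in this assay.

Compound 1 stands at the highest of the two numbers; compound 2 lies at a lower number, and the gap between them is beyond the scatter. Compound 2 differs from compound 1 in more than one place, so the pair says nothing about a single change and is left aside for the step below.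

Compound 3, `CN1CCN(c2nc(N)nc(CCCOc3cccc(Cl)c3Cl)n2)CC1`, is not yet measured. It differs from compound 1 by 2,3-dichlorophenyl in place of 3,4-dichlorophenyl on an oxygen on a saturated carbon. Among the compounds with values here, no measured pair shows this change on the shared core, so there is no direct precedent. The expected step is a 1.2-fold lower number from compound 1 to compound 3 (0.07 log units; within the scatter) in this assay, small and not clearly beyond the scatter in either direction. Compound 3 is therefore estimated at 900 nM, with a range from 300 nM to 2700 nM.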

Compound 3, inhibition constant: 274 nM
The estimate for compound 3 lay 3.3-fold (0.52 log units) above the measured number; the whole stated range lies above it.
By their numbers in this assay, from the lowest: compound 2; then compound 3; then compound 1.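

In this assay, within the data shown here, 2,3-dichlorophenyl in place of 3,4-dichlorophenyl on an oxygen on a saturated carbon gives a 3.9-fold lower number from compound 1 to compound 3 (0.59 log units; beyond the scatter), the first single-place step. The leaving and entering groups have the same atoms and the same counts, so this position responds to how the chlorine atoms are placed on the ring, at least on the core and chain of compound 1. No measurement here accounts for the step.

Among these compounds, whether the step carries over to a branched chain such as the one in compound 2 stays open. Also open, going by these compounds, is how this position takes an unsubstituted phenyl, a monochlorophenyl or a methoxyphenyl, and whether a longer chain to the oxygen changes the size of the step.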